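Growth inhibition series: adding methoxy to compound 3

This account rests on a few compounds, and the source may have more. Where it says the series, first, only, none or still open, it means among the compounds named here.

Measured so far in a functional assay on SK-MEL-5 cells (Homo sapiens) for inhibition, read by sulforhodamine B assay, with a stated time of 48 h, tested at 10 uM; on this read-out lower numbers stand for less inhibition of growth and higher numbers for more inhibition of growth at the one concentration tested:
- compound 1 `COc1ccc(-c2nc3sc(-c4ccccc4)cn3n2)cc1` gives 65%
- compound 2 `COc1cc(-c2nc3sc(-c4ccccc4)cn3n2)cc(OC)c1OC` gives 41%
- compound 3 `Clc1ccc(-c2cn3nc(-c4ccccc4)nc3s2)cc1` gives 21%

Compound 3 stands lowest of the three in this assay, with compound 2 nearest and compound 1 furthest. Both gaps lie beyond the usual scatter of repeated measurements.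

The next compound to be read is compound 4 `COc1ccc(-c2nc3sc(-c4ccc(Cl)cc4)cn3n2)cc1`. It follows from compound 3 by one change: methoxy in place of hydrogen on an aromatic carbon. This puts methoxy in place of hydrogen on an aromatic carbon, para to a large group.

Within the data shown here, no pair of measured compounds isolates this change, so its size cannot be read directly from the data. Among the measured compounds shown here, the only indirect guide is that both measured compounds with methoxy groups sit above compound 3: compound 1 gives 65% and compound 2 gives 41% in this assay. These two compounds also differ from compound 3 in other ways, so the guide is weak. An upward step beyond the scatter is expected, with wide uncertainty on its size.

The expected move is a number 29 percentage points higher from compound 3 to compound 4 (beyond the scatter) in this assay. Compound 4 is estimated at 50%, with an expected range of 25% to 75%.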

Compound 4, percent growth inhibition at one concentration: 27.5%
Estimate against measurement, compound 4: 22.5 percentage points above; measured number inside the range.
By their numbers in this assay, from the lowest: compounds 3 and 4 (each within the scatter of the next); then compound 2; then compound 1.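

With chloro already in place, methoxy in place of hydrogen on an aromatic carbon, para to a large group, gives a number 6.5 percentage points higher from compound 3 to compound 4 (within the scatter) in this assay at this position, so this pair shows no change in growth inhibition beyond the usual scatter. Chloro in place of hydrogen on an aromatic carbon gives a number 37.5 percentage points lower from compound 1 to compound 4 (beyond the scatter) in this assay with methoxy held constant, which is the first single-place step in the series to lie beyond the scatter and shows that this read-out responds to the chloro change on the methoxy-bearing compound. No measured evidence on either change bears on this result.

On these data alone, what methoxy does on a version of the core with hydrogen in place of chloro remains open, so it is not settled whether the step seen here holds without chloro. Also open, as far as these compounds go, is whether an amine, a carboxylic acid or a longer chain such as ethoxy at the methoxy position would move the read-out beyond the scatter in this assay at the one concentration tested.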